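From Pentyl to Benzyl on the Amide Nitrogen

A few compounds are considered here, and "the series" means these few. Any claim that something is new, unique, unknown or untested is made for them only; others in the source may bear on it.

In a functional assay on MDA-MB-231 cells (Homo sapiens) for cytotoxicity, read by MTT assay, with a stated time of 48 h (on this read-out higher numbers stand for weaker inhibition and lower numbers for stronger inhibition), compound 1 `CCCCNC(=O)CC[C@H](NS(=O)(=O)c1ccc([N+](=O)[O-])cc1)C(=O)O` reports only a limit of > 500000 nM and no number. Within the data shown here, compound 2 `CCCCCNC(=O)CC[C@H](NS(=O)(=O)c1ccc([N+](=O)[O-])cc1)C(=O)O` gives 162000 nM and so holds the only true number so far, with nothing else to rank it against. Compound 3 `O=C(CC[C@H](NS(=O)(=O)c1ccc([N+](=O)[O-])cc1)C(=O)O)NCc1ccccc1` has not yet been measured. Its difference from compound 2 is phenyl in place of butyl on a saturated chain carbon bound to an amide-type nitrogen, which reads as pentyl to benzyl when cut one bond further out. Among the measured compounds shown here, only one measured step bears on this change, an at least 3.0-fold lower number from compound 1 to compound 2 (0.48 log units; beyond the scatter) and it concerns a methyl in place of hydrogen on the chain. That step shows the chain can move the number in this assay but offers no direct guide to an aromatic ring. The expected move is a 1.2-fold higher number from compound 2 to compound 3 (0.09 log units; within the scatter) and thus no step beyond the scatter is expected, with only a slight lean toward a higher number. For compound 3 the estimate is 200000 nM with an expected range of 70000 nM to 500000 nM in this read-out.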

Compound 3, half-maximal inhibitory concentration: 175000 nM
For compound 3 the middle estimate is 1.1-fold (0.06 log units) above the measured one; low and high end bracket the measured number.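

In this assay phenyl in place of butyl on a saturated chain carbon bound to an amide-type nitrogen gives a 1.1-fold higher number from compound 2 to compound 3 (0.03 log units; within the scatter) so a six-membered aromatic ring at this place can stand in for the pentyl chain without a change that can be read, something the chain step alone could not show. The benzyl amide also keeps its distance from the butyl amide, with an at least 2.8-fold lower number from compound 1 to compound 3 (0.45 log units; beyond the scatter) and this matches the pentyl amide in direction, so two quite different groups at this place part from the butyl amide in the same way. That distance remains a bound and not a measured size, because compound 1 reports a limit and no number: the limit of > 500000 nM in this assay, at which 1 of the 3 values shown sits.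

The compounds shown leave open whether a longer chain such as hexyl, or a chlorine atom or methoxy group on the benzyl ring, would move the number beyond the scatter. They also leave open whether an amine or a carboxylic acid at the end of this group would do so, in either direction.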